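This account rests on a few compounds, and the source may have more. Where it says the series, first, only, none or still open, it means among the compounds named here.

Compound 1, `CC(=O)N1CCc2nc(C#Cc3ccccc3)sc2C1`, in an assay on HEK293 cells for negative allosteric modulation of metabotropic glutamate receptor 5 (Homo sapiens), read by FLIPR, with a stated time of 1 h (a higher number here means a weaker inhibitor, a lower number a stronger inhibitor), gives 90 nM.
Compound 2, `Cc1nc(C(=O)N2CCc3nc(C#Cc4ccccc4)sc3C2)cs1`, in this assay gives only > 10000 nM, which is a limit of the measurement and not a number.

Compound 2 thus stands at the limit of > 10000 nM in this assay, at which 1 of the 2 values shown sits. Among the measured compounds shown here, the only measured step, an at least 110-fold higher number from compound 1 to compound 2 (2.04 log units; beyond the scatter), went toward a weaker inhibitor when the group on the carbonyl carbon was enlarged. Compound 3, `CC(C)S(=O)(=O)N1CCc2nc(C#Cc3ccccc3)sc2C1`, differs from compound 2 by isopropylsulfonyl in place of (2-methyl-1,3-thiazol-4-yl)carbonyl on an amine nitrogen in a ring, so the enlarged group is removed again. In this assay compound 3 is therefore expected to give about 200 nM, between 40 nM and 3000 nM, an estimated step of an at least 50-fold lower number from compound 2 to compound 3 (1.69 log units; beyond the scatter).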

Compound 3, half-maximal inhibitory concentration: 11 nM
Compound 3: middle estimate off by 18-fold (1.26 log units), on the high side, outside the stated range (below it).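

On the amine nitrogen in the ring, the outcome depends strongly on the group attached: isopropylsulfonyl in place of (2-methyl-1,3-thiazol-4-yl)carbonyl gives an at least 900-fold lower number from compound 2 to compound 3 (2.95 log units; beyond the scatter), and in place of acetyl it gives an 8.2-fold lower number from compound 1 to compound 3 (0.91 log units; beyond the scatter). Compound 3 is thus the strongest inhibitor of the three, so replacing acetyl at this position can improve on it as well as abolish measurable activity. The first of these steps rests on a limit for compound 2: the limit of > 10000 nM in this assay, at which 1 of the 3 values shown sits.

The compounds shown leave open whether the gain comes from the sulfonyl link or from the isopropyl group. A methylsulfonyl or an isobutyryl group on this nitrogen would separate the two.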